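Furan-2-yl in place of phenyl on the shared core

A few compounds are considered here, and "the series" means these few. Any claim that something is new, unique, unknown or untested is made for them only; others in the source may bear on it.

Compound 3 `Oc1ccc(-c2cc(-c3ccccc3)nc(-c3ccc(Cl)cc3)c2)cc1` gives 6920 nM in a functional assay on HCT-15 cells (Homo sapiens) for cytotoxicity, read by CCK-8 assay and cell counting, with a stated time of 2 days; a higher number here means a weaker inhibitor, a lower number a stronger inhibitor. Among the three measured compounds this is the second highest number. Compound 2 `Oc1ccc(-c2cc(-c3ccc(Cl)cc3)nc(-c3ccsc3)c2)cc1` gives 6240 nM in this assay; the step of a 1.1-fold higher number from compound 2 to compound 3 (0.04 log units; within the scatter) lies within the scatter. Compound 1 `Oc1ccc(-c2cc(-c3ccc(Cl)cc3)nc(-c3cccnc3)c2)cc1` gives 20700 nM in this assay, the furthest of the three from compound 3; the step of a 3.0-fold lower number from compound 1 to compound 3 (0.48 log units; beyond the scatter) is beyond the scatter.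

Compound 4 `Oc1ccc(-c2cc(-c3ccc(Cl)cc3)nc(-c3ccco3)c2)cc1` has not been measured. It differs from compound 3 by furan-2-yl in place of phenyl on an aromatic carbon. For the measured compounds named here, two measured steps bear on this exchange. The step of a 3.3-fold lower number from compound 1 to compound 2 (0.52 log units; beyond the scatter) shows that a five-membered aromatic ring with one hetero atom in that position gives a lower number than pyridin-3-yl. The step of a 1.1-fold higher number from compound 2 to compound 3 (0.04 log units; within the scatter) shows that thiophen-3-yl and phenyl give numbers within the scatter of each other. Furan-2-yl shares with pyridin-3-yl one hydrogen-bond acceptor, but it also shares the five-membered ring with thiophen-3-yl, and only one compound of each kind is available, so the closer precedent is taken to be the step within the scatter.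

In this assay no step beyond the scatter is expected; the expected step is a 1.0-fold higher number from compound 3 to compound 4 (0.00 log units; within the scatter). Compound 4 is therefore estimated at 7000 nM, with a range from 2500 nM to 20000 nM.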

Compound 4, half-maximal inhibitory concentration: 7020 nM
Compound 4: middle estimate off by 1.0-fold (0.00 log units), on the low side, within the range that was stated.
By their numbers in this assay, from the lowest: compounds 2, 3 and 4 (each within the scatter of the next); then compound 1.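

In this assay the exchange on the aromatic carbon next to the ring nitrogen now has a third ring to compare: the step of a 1.0-fold higher number from compound 3 to compound 4 (0.01 log units; within the scatter) and the step of a 1.1-fold higher number from compound 2 to compound 4 (0.05 log units; within the scatter) both lie within the scatter, so phenyl, thiophen-3-yl and furan-2-yl cannot be told apart here, whether the ring is six- or five-membered and whether its hetero atom is sulfur or oxygen. Furan-2-yl counts one hydrogen-bond acceptor and phenyl none, yet that difference comes with no step beyond the scatter, while the step of a 2.9-fold lower number from compound 1 to compound 4 (0.47 log units; beyond the scatter) leaves compound 1 as the only one of the four set apart, so among these compounds an acceptor in the ring does not by itself go with the number of compound 1. Nothing on hand explains why pyridin-3-yl stands apart from the other three rings.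

As far as these compounds go, all four groups at this position are aromatic rings, so it stays open whether an aliphatic amine, a carboxylic acid or a longer alkyl chain there would stay with phenyl or fall with pyridin-3-yl. Pyridin-2-yl and pyridin-4-yl would show whether the step from compound 1 is tied to where the ring nitrogen sits.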